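A few compounds are considered here, and "the series" means these few. Any claim that something is new, unique, unknown or untested is made for them only; others in the source may bear on it.

Three compounds share one core and differ only in the group carried on a saturated ring carbon of the six-membered ring that holds a nitrogen. In an assay on CHO cells for displacement of a labelled ligand from 5-hydroxytryptamine receptor 1D (Homo sapiens) (on this read-out higher numbers stand for weaker inhibition and lower numbers for stronger inhibition), compound 1 `CC(C)=CCCN(C)C1CCN(CCCc2c[nH]c3ccc(-n4cnnc4)cc23)CC1` gives 2.6 nM. Compound 2 `CN(Cc1cccs1)C1CCN(CCCc2c[nH]c3ccc(-n4cnnc4)cc23)CC1` gives 4.3 nM, and compound 3 `c1ccc2c(c1)CCC2NC1CCN(CCCc2c[nH]c3ccc(-n4cnnc4)cc23)CC1` gives 8.9 nM. Compound 3 thus stands with the highest number of the three: there is a 2.1-fold higher number from compound 2 to compound 3 (0.32 log units; beyond the scatter) and a 3.4-fold higher number from compound 1 to compound 3 (0.53 log units; beyond the scatter), both beyond the scatter, while a 1.7-fold higher number from compound 1 to compound 2 (0.22 log units; within the scatter).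

Compound 4 `CN(Cc1ccsc1)C1CCN(CCCc2c[nH]c3ccc(-n4cnnc4)cc23)CC1` has not yet been measured. It differs from compound 3 by methyl((thiophen-3-yl)methyl)amino in place of (2,3-dihydro-1H-inden-1-yl)amino on a saturated ring carbon. This change is close to the reverse of the step from compound 2 to compound 3, the one difference being that the ring is joined as thiophen-3-yl rather than thiophen-2-yl. The step that bears on it most directly is a 2.1-fold higher number from compound 2 to compound 3 (0.32 log units; beyond the scatter); the step of a 3.4-fold higher number from compound 1 to compound 3 (0.53 log units; beyond the scatter) likewise shows that a methyl group on the amine nitrogen together with a short side chain gave a lower number than compound 3. Run backwards, these steps point to a modest lowering of the number, with the changed point of attachment adding some uncertainty.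

Compound 4 is therefore expected to give 4.5 nM in this assay, within a range from 2 nM to 10 nM. That estimate means an expected step of a 2.0-fold lower number from compound 3 to compound 4 (0.30 log units; within the scatter), modest and toward a lower number.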

Compound 4, half-maximal inhibitory concentration: 1.5 nM
Estimate against measurement, compound 4: 3.0-fold (0.48 log units) above; the whole stated range lies above it.
By their numbers in this assay, from the lowest: compounds 4, 1 and 2 (each within the scatter of the next, the first and the last beyond it); then compound 3.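

In this assay, among these compounds, the point of attachment on the thiophene ring matters at this position: thiophen-3-yl in place of thiophen-2-yl gives a 2.9-fold lower number from compound 2 to compound 4 (0.46 log units; beyond the scatter), a difference the earlier compounds, which held only the thiophen-2-yl form, could not show. The new group also widens the gap to the (2,3-dihydro-1H-inden-1-yl)amino group of compound 3, with a 5.9-fold lower number from compound 3 to compound 4 (0.77 log units; beyond the scatter), whereas a 1.7-fold lower number from compound 1 to compound 4 (0.24 log units; within the scatter) leaves compound 4 and compound 1 level, so an open chain and a thiophen-3-yl ring on the same methyl-bearing amine cannot be told apart here. No measurement offered here explains why the point of attachment changes the result.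

The change from compound 3 to compound 4 swaps the whole group at once, so the share of the methyl on the amine nitrogen and the share of the thiophen-3-yl ring remain unseparated; a thiophen-3-ylmethyl amine carrying hydrogen or ethyl in place of that methyl would bear on this. On these data alone, whether a furan-3-yl ring, with oxygen in place of sulfur, would match thiophen-3-yl also stays open.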